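This account rests on a few compounds, and the source may have more. Where it says the series, first, only, none or still open, it means among the compounds named here.

Compound 1 `CCCCOc1ccc(-c2cncc(C(=O)O)c2)cc1CNC(=O)c1ccc(C(F)(F)F)cc1F` gives 9030 ug/mL
Compound 2 `CCCCOc1ccc(-c2c(F)ccc(C(=O)O)c2F)cc1CNC(=O)c1ccc(C(F)(F)F)cc1F` gives 10400 ug/mL

In a physicochemical assay for solubility, measured as thermodynamic solubility (on this read-out lower numbers stand for lower solubility and higher numbers for higher solubility), compound 2 gives 10400 ug/mL and sits within the scatter of compound 1. Compound 3 `CCCCOc1ccc(-c2ccc(C(=O)O)cc2F)cc1CNC(=O)c1ccc(C(F)(F)F)cc1F` carries 4-carboxy-2-fluorophenyl in place of 3-carboxy-2,6-difluorophenyl on an aromatic carbon, para to a butoxy group (4-carboxy-2-fluorophenyl in place of 3-carboxy-2,6-difluorophenyl on an aromatic carbon). Among the measured compounds shown here, only one measured step bears on this: exchanging the group on that same carbon gave a 1.2-fold higher number from compound 1 to compound 2 (0.06 log units; within the scatter) and stayed within the scatter. No step beyond the scatter is therefore expected and no direction is favoured, so the estimated change is a 1.1-fold lower number from compound 2 to compound 3 (0.04 log units; within the scatter) in this assay for this swap. Compound 3 is estimated at 9500 ug/mL with 4500 ug/mL to 18000 ug/mL as its range.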

Compound 3, solubility: 3220 ug/mL
For compound 3 the middle estimate is 3.0-fold (0.47 log units) above the measured one; measured number outside the range, below it.
By their numbers in this assay, from the lowest: compound 3; then compounds 1 and 2 (each within the scatter of the next).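

In this assay this position proves sensitive to the group it carries: 4-carboxy-2-fluorophenyl gives a 3.2-fold lower number from compound 2 to compound 3 (0.51 log units; beyond the scatter) and a 2.8-fold lower number from compound 1 to compound 3 (0.45 log units; beyond the scatter) while the earlier exchange on this carbon stayed within the scatter. No measurement shown accounts for this drop. The entering group differs from 3-carboxy-2,6-difluorophenyl both in where its carboxy group sits and in its fluorine count, and the compounds shown cannot separate those two changes. They also leave open how a tetrazole in place of the carboxylic acid would behave here.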